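This account rests on a few compounds, and the source may have more. Where it says the series, first, only, none or still open, it means among the compounds named here.

Three compounds built on a shared core have been examined in a functional assay on BGC-823 cells (Homo sapiens) for inhibition, read by MTT assay, with a stated time of 72 h; on this read-out lower numbers stand for stronger inhibition and higher numbers for weaker inhibition. Compound 1 `Cc1nc2nc(SCc3ccc(Cl)cc3)nn2c(N2CC[C@@H](C)[C@@H](N(C)c3ncnc4[nH]ccc34)C2)c1C` returns only a limit of the assay rather than a number, > 100000 nM, and that is all this value tells (the limit of > 100000 nM in this assay, at which 1 of the 3 values shown sits). Compound 2 `Cc1cc(N2CC[C@@H](C)[C@@H](N(C)c3ncnc4[nH]ccc34)C2)n2nc(SCC3CCCCC3)nc2n1` gives 16300 nM, and compound 3 `CCc1cc(N2CC[C@@H](C)[C@@H](N(C)c3ncnc4[nH]ccc34)C2)n2ncnc2n1` gives 82200 nM. Of the two numbers actually measured, compound 2 stands at the lower one, meaning the stronger inhibition, and its gap to compound 3 lies beyond the usual scatter of repeated measurements.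

Compound 4 `C#CSc1nc2nc(C)cc(N3CC[C@@H](C)[C@@H](N(C)c4ncnc5[nH]ccc45)C3)n2n1` has not been measured yet. It is related to compound 2 by a single change: ethynyl in place of cyclohexylmethyl on a sulfur. The cyclohexylmethyl group that leaves is the larger of the two, and the ethynyl group that enters is much smaller. Going by the values given here, no pair of measured compounds differs at this one place alone, so the size of the step can only be anticipated from the three values at hand. Among the compounds with values here, compound 2 is the only one whose number falls well short of the assay's limit, while compound 3 sits near it and compound 1 at it; on that basis the expected step is a 3.1-fold higher number from compound 2 to compound 4 (0.49 log units; beyond the scatter), towards weaker inhibition. Compound 4 is thus estimated to give about 50000 nM, most likely between 15000 nM and 150000 nM, with a real chance that this assay reports only a limit.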

Compound 4, half-maximal inhibitory concentration: 62100 nM
Compound 4: middle estimate off by 1.2-fold (0.09 log units), on the low side; the range from low to high includes it.
By their numbers in this assay, from the lowest: compound 2; then compounds 4 and 3 (each within the scatter of the next). At a limit, above all of these: compound 1.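

In this assay, exchanging cyclohexylmethyl for ethynyl on the sulfur gives a 3.8-fold higher number from compound 2 to compound 4 (0.58 log units; beyond the scatter), towards weaker inhibition. Going by these compounds alone, this is the first direct reading of this position, as the earlier compounds differ from one another in more than one place, and it shows that the group on the sulfur does affect the read-out. The change shortens the group from 7 heavy atoms to 2 and removes the ring, yet compound 4 still gives a measured number rather than a limit, so the step can be read in full, and the one limit remains with compound 1: the limit of > 100000 nM in this assay, at which 1 of the 4 values shown sits.

Two groups at one place cannot show whether the difference follows the size of the group, the presence of the ring or the triple bond, and a straight butyl chain on the same sulfur would help to separate these. Going by these compounds, how a carboxylic acid or an amine at the end of such a chain would behave also stays open, as does whether this step would be the same on the cores of compound 1 or compound 3.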